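Moving the methyl around the phenylurea

The source may report more compounds than this note shows. Statements on the series, on what has been measured and on what is new or still open speak of the compounds shown alone.

Compound 2 `COc1ccc(-c2cnc3nc(N)nc(N4CCN(C(=O)Nc5ccc(C)cc5)CC4)c3n2)cc1OC` — 0.8 nM
Compound 1 `COc1ccc(-c2cnc3nc(N)nc(N4CCN(C(=O)Nc5ccccc5)CC4)c3n2)cc1OC` — 3.4 nM

The two measured compounds share one core and differ only on the urea-bound phenyl ring. In a functional assay on cells (T-cell, Homo sapiens) for inhibition (on this read-out higher numbers stand for weaker inhibition and lower numbers for stronger inhibition), compound 1 gives 3.4 nM, and compound 2 gives 0.8 nM. Within the data shown here, the one measured step, a 4.3-fold lower number from compound 1 to compound 2 (0.63 log units; beyond the scatter), comes with methyl in place of hydrogen on an aromatic carbon. Among the measured compounds shown here, compound 2 therefore stands at the lowest of the two numbers, with compound 1 as its only neighbour.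

Compound 3 `COc1ccc(-c2cnc3nc(N)nc(N4CCN(C(=O)Nc5cccc(C)c5)CC4)c3n2)cc1OC` is not yet measured in this assay. It differs from compound 2 by 3-methylphenyl in place of 4-methylphenyl on an amide-type nitrogen. On these data alone, the measured step says only that a methyl on this ring matters; it says nothing about the 3-methylphenyl against the 4-methylphenyl, so the change is untested here. Since the methyl is kept, compound 3 is expected to stay closer to compound 2 than to compound 1, while a move away from the measured position leaves room for some loss. The account therefore expects a step of a 1.9-fold higher number from compound 2 to compound 3 (0.27 log units; within the scatter), within or just beyond the scatter. Compound 3 is estimated at 1.5 nM, between 0.5 nM and 5 nM.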

Compound 3, half-maximal inhibitory concentration: 7 nM
The estimate for compound 3 lay 4.7-fold (0.67 log units) below the measured number; the measured number lies above the stated range.
By their numbers in this assay, from the lowest: compound 2; then compound 1; then compound 3.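

In this assay, 3-methylphenyl in place of 4-methylphenyl on an amide-type nitrogen gives an 8.8-fold higher number from compound 2 to compound 3 (0.94 log units; beyond the scatter), although the two compounds have the same atoms, joined differently, and the two groups match in every count taken. Compared with the plain phenyl, the same methyl in place of hydrogen on an aromatic carbon now gives a 2.1-fold higher number from compound 1 to compound 3 (0.31 log units; beyond the scatter), the opposite direction from a 4.3-fold lower number from compound 1 to compound 2 (0.63 log units; beyond the scatter), so among these three compounds the gain belongs to the 4-methylphenyl and not to a methyl on this ring as such. Nothing available here accounts for this dependence on where the methyl stands.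

The compounds shown leave open whether the gain goes with the methyl itself or would also appear with another group in its place on the 4-methylphenyl ring, such as a chlorine atom, a methoxy group or an ethyl group. They also leave open whether the loss seen with 3-methylphenyl is particular to the methyl, or whether a chlorine atom or a methoxy group on the ring in that form would give a similar number.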